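Indolyl replacement on the exocyclic aryl of the pyrazolidinedione series

This account rests on a few compounds, and the source may have more. Where it says the series, first, only, none or still open, it means among the compounds named here.

Compound 2 `O=C1C(=Cc2cccc(Cl)c2)C(=O)N(c2ccc(Cl)cc2)N1c1ccc(Cl)cc1` carries the higher of the two numbers in hand. In a functional assay on ECa-109 cells (Homo sapiens) for cytotoxicity, read by MTT assay, with a stated time of 72 h (a higher number here means a weaker inhibitor, a lower number a stronger inhibitor), compound 2 gives 22600 nM, while compound 1 `COc1cc(C=C2C(=O)N(c3ccc(Cl)cc3)N(c3ccc(Cl)cc3)C2=O)ccc1O` gives 7100 nM. Among the compounds with values here, the one measured step connects them: a 3.2-fold higher number from compound 1 to compound 2 (0.50 log units; beyond the scatter).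

Compound 3 `O=C1C(=Cc2c[nH]c3ccccc23)C(=O)N(c2ccc(Cl)cc2)N1c1ccc(Cl)cc1` has not been measured. It differs from compound 2 by 1H-indol-3-yl in place of 3-chlorophenyl on a double-bonded chain carbon bound to a double-bonded ring carbon. Within the data shown here, the change therefore sits at the same place where the only measured step was taken, so that step is the one that bears on it; it was modest in size and showed that swapping the aryl group on the double-bonded chain carbon moves the number beyond the scatter. Among the measured compounds shown here, there is no measured compound with a 1H-indol-3-yl group, so the direction is uncertain. The aryl with a hydrogen-bond donor, compound 1, gave the lower number, and the entering group also carries one donor; a modest move toward a lower number is therefore expected, with wide uncertainty, as a 2.3-fold lower number from compound 2 to compound 3 (0.35 log units; beyond the scatter).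

For compound 3 in this assay the estimate is 10000 nM, within 3000 nM to 35000 nM.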

Compound 3, half-maximal inhibitory concentration: 23400 nM
For compound 3 the middle estimate is 2.3-fold (0.37 log units) below the measured one, within the range that was stated.
By their numbers in this assay, from the lowest: compound 1; then compounds 2 and 3 (each within the scatter of the next).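

In this assay, the step to 1H-indol-3-yl reads a 1.0-fold higher number from compound 2 to compound 3 (0.02 log units; within the scatter), so on the double-bonded chain carbon bound to a double-bonded ring carbon, this group and 3-chlorophenyl cannot be told apart, even though 1H-indol-3-yl brings a hydrogen-bond donor and a five-membered aromatic ring that 3-chlorophenyl lacks. Against 4-hydroxy-3-methoxyphenyl the step reads a 3.3-fold higher number from compound 1 to compound 3 (0.52 log units; beyond the scatter), which leaves compound 1 alone at the low end of the three and makes compound 3 a clear exception to any link between a hydrogen-bond donor on this aryl group and a lower number. Nothing on hand bears on the reason for these readings.

The compounds shown leave open whether the hydroxy or the methoxy of 4-hydroxy-3-methoxyphenyl goes with the lower number of compound 1, as the two change only together here. Also open, from the compounds shown here alone, is how a phenyl group bearing an amine or a carboxylic acid would read at this place on the shared core.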